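Thiophen-3-yl on the thiophene arm: cytotoxicity outlook

This account rests on a few compounds, and the source may have more. Where it says the series, first, only, none or still open, it means among the compounds named here.

Compound 3 `C=Cc1csc(CN[C@@H]2C[C@H]3C[C@@H]([C@H]2C)C3(C)C)c1` gives 6250 nM in an ADME assay on MDCK cells (Canis lupus familiaris) for cytotoxicity, read by microscopy, with a stated time of 48 h (a lower number here means that less compound is tolerated, a higher number that more compound is tolerated), and stands level with compound 2 `C[C@H]1[C@H](NCc2cc(Br)cs2)C[C@H]2C[C@@H]1C2(C)C`, which gives 6250 nM; together these are the lowest of the three numbers, while compound 1 `C[C@H]1[C@H](NCc2cc(C3CC3)cs2)C[C@H]2C[C@@H]1C2(C)C` gives 25000 nM, a step of a 4.0-fold lower number from compound 1 to compound 3 (0.60 log units; beyond the scatter). Compound 4 `C[C@H]1[C@H](NCc2cc(-c3ccsc3)cs2)C[C@H]2C[C@@H]1C2(C)C` carries thiophen-3-yl in place of vinyl on an aromatic carbon. For the measured compounds named here, of the measured steps, no change at the digits printed from compound 2 to compound 3 (within the scatter) and a 4.0-fold lower number from compound 1 to compound 3 (0.60 log units; beyond the scatter) both exchange a small substituent at the same aromatic carbon; no measured step brings in an aromatic ring. Since the larger group in compound 1 went with the higher number, seen in a 4.0-fold lower number from compound 1 to compound 3 (0.60 log units; beyond the scatter), a modest upward step is expected, a 2.0-fold higher number from compound 3 to compound 4 (0.30 log units; within the scatter), though a step within the scatter remains possible. For compound 4 the estimate in this assay is 12500 nM, with a range from 6250 nM to 50000 nM.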

Compound 4, minimum cytotoxic concentration: 25000 nM
Beside the measured number, compound 4's estimate is 2.0-fold (0.30 log units) below it; the measured number falls inside the stated range.
By their numbers in this assay, from the lowest: compounds 2 and 3 (each within the scatter of the next); then compounds 1 and 4 (each within the scatter of the next).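

At this aromatic carbon, two ring bonds from the ring sulfur, thiophen-3-yl brings the first aromatic ring, and this assay records a 4.0-fold higher number from compound 3 to compound 4 (0.60 log units; beyond the scatter) and a 4.0-fold higher number from compound 2 to compound 4 (0.60 log units; beyond the scatter) for this change. The comparison with cyclopropyl gives no change at the digits printed from compound 1 to compound 4 (within the scatter), so among these four compounds the two ring-bearing groups stand together, apart from vinyl and bromo, with no compound against this split. No evidence at hand accounts for it. Open, on these data alone, is whether phenyl would stand with thiophen-3-yl, and how a carboxylic acid or a longer alkyl chain would read at this carbon.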